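The source may hold more compounds than are shown below. What is called first, only, known or untested is meant among the compounds shown, and "the series" means these compounds.

Of the compounds shown here, two have been tested in an assay on isolated protein for binding affinity to Sigma non-opioid intracellular receptor 1 (Rattus norvegicus); a higher number here means a weaker inhibitor, a lower number a stronger inhibitor. Compound 1 `C=CCN1CCc2ccsc2C1c1ccccc1` gives 20000 nM. Compound 2 `CC(C)C1NCCc2ccsc21` gives 3800 nM, the lowest of the two numbers, set apart from compound 1 by a gap beyond the scatter. Compound 3 `C=CCN1CCc2ccsc2C1C(C)C` is not yet measured; it keeps the core of compound 2 and carries allyl in place of hydrogen on an amine nitrogen in a ring. For the measured compounds named here, no measured pair isolates this change, so the size of the step is open. A small shift toward a weaker number is expected, about a 1.4-fold higher number from compound 2 to compound 3 (0.16 log units; within the scatter), within the scatter. Compound 3 is estimated at 5500 nM, with a range from 1500 nM to 20000 nM.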

Compound 3, half-maximal inhibitory concentration: 5000 nM
Estimate against measurement, compound 3: 1.1-fold (0.04 log units) above; the range from low to high includes it.
By their numbers in this assay, from the lowest: compounds 2 and 3 (each within the scatter of the next); then compound 1.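

In this assay allyl in place of hydrogen on an amine nitrogen in a ring gives a 1.3-fold higher number from compound 2 to compound 3 (0.12 log units; within the scatter) so compound 2 and compound 3 cannot be told apart at this nitrogen. With allyl present on that nitrogen, isopropyl in place of phenyl on a saturated ring carbon gives a 4.0-fold lower number from compound 1 to compound 3 (0.60 log units; beyond the scatter) and this is a real, modest difference. Nothing here explains either step. Still open, as far as these compounds go, is whether a longer chain or a benzyl group on the nitrogen would also match compound 2. From the compounds shown here alone, it is also open whether allyl would give a similar step with phenyl on the ring carbon.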